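From (4-iodophenyl)sulfanyl to 3-iodophenoxy

The source may hold more compounds than are shown below. What is called first, only, known or untested is meant among the compounds shown, and "the series" means these compounds.

In a physicochemical assay, in phosphate buffer, with a stated time of 24 h, at pH 7.4 (a higher number here means that more of the compound is left, a lower number that less of the compound is left), compound 1 `COC1=CC(=O)c2c(c(COc3ccc(I)cc3)c(C)n2C)C1=O` gives > 90%, which is a limit. Compound 2 `COC1=CC(=O)c2c(c(CSc3ccc(I)cc3)c(C)n2C)C1=O` gives > 90%, also a limit. Compound 2 therefore stands at the limit of > 90% in this assay, at which 2 of the 2 values shown sit. Going by the values given here, the only measured step is a step that the two limits leave unreadable from compound 1 to compound 2, so no size can be carried forward from it.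

Compound 3 `COC1=CC(=O)c2c(c(COc3cccc(I)c3)c(C)n2C)C1=O` brings one change: 3-iodophenoxy in place of (4-iodophenyl)sulfanyl on a saturated chain carbon bound to an aromatic carbon. With both measured compounds at the limit, no shift beyond the scatter is expected in this assay. The expected result is a step that the limit leaves unreadable from compound 2 to compound 3. For compound 3 the estimate is 95%, with an expected range of 85% to 100%.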

Compound 3, percent of the compound remaining: > 90%
Compound 3 ended at the assay's limit; the forecaster's own chance of this, stated with the estimate: 70%; the middle value does not contradict the limit.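

Compound 2 and compound 3 both end at a limit, as does compound 1, so no step among these compounds can be read: the limit of > 90% in this assay, at which 3 of the 3 values shown sit.

Going by these compounds, whether 4-iodophenoxy, (4-iodophenyl)sulfanyl and 3-iodophenoxy differ at all in this assay stays open.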